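The source may report more compounds than this note shows. Statements on the series, on what has been measured and on what is new or still open speak of the compounds shown alone.

Working notes on the series. Three compounds have been run in a functional assay on NCI-H23 cells (Homo sapiens) for cytotoxicity, read by sulforhodamine B assay, with a stated time of 72 h; a higher number here means a weaker inhibitor of growth, a lower number a stronger inhibitor of growth. Compound 1 `CCCCCCCCC(=O)N1c2ccccc2CCC1C(=O)Nc1ccccc1O` gives 55800 nM in this assay. Compound 2 `CCCC(=O)N1c2ccccc2CCC1C(=O)Nc1cc(C(F)(F)F)cc(C(F)(F)F)c1` gives 15000 nM in this assay. Compound 3 `CC(=O)N1c2ccccc2CCC1C(=O)Nc1ccccc1C(F)(F)F` reaches only a limit of this assay, > 80000 nM, and no number is obtained for it (the limit of > 80000 nM in this assay, at which 1 of the 3 values shown sits). Among the two numbers in hand, compound 2 stands lowest, and the nearest number, that of compound 1, lies beyond the scatter above it. Among the compounds with values here, no two measured compounds differ in a single place, so no measured step is available to lean on.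

The compound still to be measured is compound 4 `CCC(=O)N1c2ccccc2CCC1C(=O)Nc1cc(C(F)(F)F)cc(C(F)(F)F)c1`. It differs from compound 2 in one place (hydrogen in place of methyl on a saturated chain carbon, two bonds along the chain from a carbonyl carbon), so that the propylcarbonyl of compound 2 becomes a propanoyl in compound 4. Within the data shown here, as no measured pair shows this change alone, the expectation rests on the change itself, which is small in count and removes no donor or acceptor; the step is expected to be slight and toward a higher number, if beyond the scatter at all, given as a 1.3-fold higher number from compound 2 to compound 4 (0.12 log units; within the scatter) in this assay. For compound 4 the expected number in this assay is 20000 nM, with a range from 8000 nM to 50000 nM.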

Compound 4, concentration for 50% growth inhibition: 7820 nM
Estimate against measurement, compound 4: 2.6-fold (0.41 log units) above; the whole stated range lies above it.
By their numbers in this assay, from the lowest: compounds 4 and 2 (each within the scatter of the next); then compound 1. At a limit, above all of these: compound 3.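

In this assay, the change from propylcarbonyl to propanoyl, with the rest of the structure held constant, gives a 1.9-fold lower number from compound 2 to compound 4 (0.28 log units; within the scatter), the first single-place step available in the series. This pair places compounds 2 and 4 within the scatter of each other, so the methyl on a saturated chain carbon, two bonds along the chain from a carbonyl carbon, is not required to keep growth inhibition in this range when the two trifluoromethyl groups of these compounds are present. No measurement shown accounts for the size of this step, and the pair gives no cause for it.

This one pair does not define a chain-length trend, and steps to compounds 1 and 3 cannot be read, as each differs from compounds 2 and 4 in more than one place. Still open, from the compounds shown here alone, is whether an acetyl or a pentanoyl group, or a chain ending in an amine or a carboxylic acid, would stay within the scatter of compounds 2 and 4 on the same amide.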